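The source may report more compounds than this note shows. Statements on the series, on what has been measured and on what is new or still open speak of the compounds shown alone.

Measured compounds:
compound 1, `CCCCc1cn(C[C@H](O)[C@H]2OC(=O)C(OCc3ccccc3)=C2OCc2ccccc2)nn1`, 7910 nM
compound 2, `COc1ccc(-c2cn(C/C=C3\OC(=O)C(OCc4ccccc4)=C3OCc3ccccc3)nn2)cc1`, 39100 nM

The study is read in a functional assay on MCF7 cells (Homo sapiens) for antiproliferative activity, read by MTT assay, with a stated time of 72 h; a higher number here means a weaker inhibitor, a lower number a stronger inhibitor. Of the two measured compounds, compound 1 gives the lower number, 7910 nM, and compound 2 gives 39100 nM; the two numbers lie apart by more than the usual scatter, so compound 1 stands as the stronger of the pair. Compound 3, `O=C1O[C@H]([C@@H](O)Cn2cc(-c3cc(F)cc(F)c3)nn2)C(OCc2ccccc2)=C1OCc1ccccc1`, has not yet been measured. It differs from compound 1 in one place: 3,5-difluorophenyl in place of butyl on an aromatic carbon. Going by the values given here, no step between measured compounds that differ in only one place is available, so there is no direct precedent for this change; compound 2, which also carries an aryl group on the triazole but differs in the linker as well, is the weaker of the two measured compounds. On that basis a modest weakening is expected, though one that may still fall within the scatter, so that the step from compound 1 to compound 3 in this assay is estimated at a 1.5-fold higher number from compound 1 to compound 3 (0.18 log units; within the scatter). Compound 3 is therefore expected to give about 12000 nM in this assay, within a range from 4000 nM to 40000 nM.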

Compound 3, half-maximal inhibitory concentration: 27700 nM
The estimate for compound 3 lay 2.3-fold (0.36 log units) below the measured number; measured number inside the range.
By their numbers in this assay, from the lowest: compound 1; then compounds 3 and 2 (each within the scatter of the next).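

Going by these compounds alone, the step gives the first direct reading of a change at this aromatic carbon of the five-membered aromatic ring with 3 nitrogen: in this assay, putting 3,5-difluorophenyl in place of butyl brings a 3.5-fold higher number from compound 1 to compound 3 (0.54 log units; beyond the scatter), so the number here does respond to the group this carbon carries. On this single pair, the butyl chain, which has no ring, goes with the lower number, and the larger aromatic group goes with the higher one. No measurement available here bears on the reason for this difference.

Whether the change follows from the aromatic ring itself or from its two fluorine atoms stays open, as a plain phenyl group is not among the compounds shown. Also open, going by these compounds, is how a longer chain or a chain ending in an amine would read at this position.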